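Chlorine placement on the benzyloxy arm

A few compounds are considered here, and "the series" means these few. Any claim that something is new, unique, unknown or untested is made for them only; others in the source may bear on it.

The three measured compounds share one core and differ on the saturated chain carbon bound to an oxygen on an aromatic ring. Compound 1 `Cc1ccc(NC(=S)NC(=O)c2ccc(OCc3cccc(C(F)(F)F)c3)cc2)cc1-c1nc2ccccc2[nH]1` carries a 3-(trifluoromethyl)phenyl there and compound 2 `Cc1ccc(NC(=S)NC(=O)c2ccc(OCc3ccc(F)cc3)cc2)cc1-c1nc2ccccc2[nH]1` a 4-fluorophenyl. In a functional assay on MGC-803 cells (Homo sapiens) for inhibition, read by MTT assay, with a stated time of 48 h (on this read-out higher numbers stand for weaker inhibition and lower numbers for stronger inhibition), compound 1 gives 5210 nM and compound 2 gives 2810 nM; a 1.9-fold lower number from compound 1 to compound 2 (0.27 log units; within the scatter). Compound 3 `Cc1ccc(NC(=O)NC(=O)c2ccc(OCc3cccc(Cl)c3)cc2)cc1-c1nc2ccccc2[nH]1` gives 20800 nM, the highest number of the three, beyond the scatter from both others. Compound 4 `Cc1ccc(NC(=O)NC(=O)c2ccc(OCc3ccccc3Cl)cc2)cc1-c1nc2ccccc2[nH]1` differs from compound 3 by 2-chlorophenyl in place of 3-chlorophenyl on a saturated chain carbon bound to an oxygen on an aromatic ring. Among the measured compounds shown here, no measured step compares two chlorophenyl groups; the only step at this carbon, a 1.9-fold lower number from compound 1 to compound 2 (0.27 log units; within the scatter), stayed within the scatter. For compound 4 a step of a 1.2-fold lower number from compound 3 to compound 4 (0.06 log units; within the scatter) is therefore expected, none beyond the scatter. Compound 4 is estimated at 18000 nM, range 7000 nM to 45000 nM.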

Compound 4, half-maximal inhibitory concentration: 19500 nM
The estimate for compound 4 lay 1.1-fold (0.03 log units) below the measured number, and the stated range covers the measured number.
By their numbers in this assay, from the lowest: compounds 2 and 1 (each within the scatter of the next); then compounds 4 and 3 (each within the scatter of the next).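

Swapping 3-chlorophenyl for 2-chlorophenyl on the saturated chain carbon bound to an oxygen on an aromatic ring reads as a 1.1-fold lower number from compound 3 to compound 4 (0.03 log units; within the scatter) in this assay and gives the first comparison of two chlorine placements at this carbon. On this read-out, those two placements cannot be told apart. Nothing on hand explains this result.

Still open, on these data alone, is how 4-chlorophenyl or a pyridine ring would read at this carbon. No pair shown isolates the thiocarbonyl of compound 1 and compound 2 from the carbonyl of compound 3 and compound 4.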